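Changing the Aryl Group on the Amide-Type Nitrogen

This account rests on a few compounds, and the source may have more. Where it says the series, first, only, none or still open, it means among the compounds named here.

Compound 1, `O=C(Nc1ccccc1)Nc1nnc(Sc2ncnc3scc(-c4ccncc4)c23)s1`, gives 23300 nM in a functional assay on T47D cells (Homo sapiens) for antiproliferative activity, read by MTT assay, with a stated time of 48 h; on this read-out higher numbers stand for weaker inhibition and lower numbers for stronger inhibition.
Compound 2, `O=C(Nc1cccc(C(F)(F)F)c1)Nc1nnc(Sc2ncnc3scc(-c4ccncc4)c23)s1`, gives 45100 nM in this assay.
Compound 3, `Cc1ccc(NC(=O)Nc2nnc(Sc3ncnc4scc(-c5ccncc5)c34)s2)cc1Cl`, gives 34800 nM in this assay.

The three measured compounds share one core and differ only in the aryl group on the amide-type nitrogen. On the numbers shown, compound 3 sits among the other two without separating from either: the change a 1.5-fold higher number from compound 1 to compound 3 (0.17 log units; within the scatter) and the change a 1.3-fold lower number from compound 2 to compound 3 (0.11 log units; within the scatter) both stay inside the usual scatter, as does a 1.9-fold higher number from compound 1 to compound 2 (0.29 log units; within the scatter). None of the three can be called stronger or weaker than another.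

Compound 4, `COc1ccc(NC(=O)Nc2nnc(Sc3ncnc4scc(-c5ccncc5)c34)s2)cc1`, carries the next variation at the same place: 4-methoxyphenyl in place of 3-chloro-4-methylphenyl on an amide-type nitrogen. Within the data shown here, the steps that bear on this are the two already seen at this position, from compound 1 to compound 3 and from compound 2 to compound 3, and both were within the scatter. Among the measured compounds shown here, nothing among the measured compounds points to a step beyond the scatter in either direction for compound 4 in this assay, so the expectation is a number close to that of compound 3.

Compound 4 is therefore estimated at 30000 nM, with a range from 12000 nM to 75000 nM. The expected step of a 1.2-fold lower number from compound 3 to compound 4 (0.06 log units; within the scatter) is within the scatter.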

Compound 4, half-maximal inhibitory concentration: > 100000 nM
Compound 4: only a limit was reported; the forecaster's own chance of this, stated with the estimate: 10%; middle value at least 3.3-fold (0.52 log units) away from the limit.
By their numbers in this assay, from the lowest: compounds 1, 3 and 2 (each within the scatter of the next). At a limit, above all of these: compound 4.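

Compound 4 is reported only as a limit, not as a number: the limit of > 100000 nM in this assay, at which 1 of the 4 values shown sits.

The position had looked flat across the first three aryl groups, but in this assay it now gives steps beyond the scatter: an at least 2.8-fold higher number from compound 3 to compound 4 (0.45 log units; beyond the scatter), an at least 2.2-fold higher number from compound 2 to compound 4 (0.34 log units; beyond the scatter) and an at least 4.2-fold higher number from compound 1 to compound 4 (0.63 log units; beyond the scatter). The aryl group on the amide-type nitrogen can therefore shift this read-out towards weaker inhibition, and the change that does so here is 4-methoxyphenyl, which counts 1 hydrogen-bond acceptor where 3-chloro-4-methylphenyl counts 0; the step from the unsubstituted phenyl shows the same thing as methoxy in place of hydrogen on an aromatic carbon.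

Going by these compounds, each of these steps is only a lower bound, so their true sizes stay unknown, and a single compound cannot show whether the methoxy itself, its place on the ring or its oxygen accounts for the loss. On these data alone, how hydroxy, ethoxy or an amine would read on the same ring remains open, as does whether a change at this nitrogen can move the number lower than the values of the other three compounds.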